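From thiophen-3-yl to 1-benzofuran-2-yl on a shared core

The source may report more compounds than this note shows. Statements on the series, on what has been measured and on what is new or still open speak of the compounds shown alone.

- Compound 1 `COc1ncnc2c1c(-c1cc3ccccc3o1)cn2[C@@H]1O[C@H](CO)[C@@H](O)[C@H]1O`: 22400 nM
- Compound 2 `Cc1ncnc2c1c(-c1ccsc1)cn2[C@@H]1O[C@H](CO)[C@@H](O)[C@H]1O`: 96900 nM

In an ADME assay on BJ cells (Homo sapiens), read by MTT assay, with a stated time of 72 h (a higher number here means a weaker inhibitor, a lower number a stronger inhibitor), compound 2 has the higher of the two numbers, 96900 nM, which makes it the weaker inhibitor of the pair. Compound 1 lies lower by more than the usual scatter of repeated measurements. Compound 3 `Cc1ncnc2c1c(-c1cc3ccccc3o1)cn2[C@@H]1O[C@H](CO)[C@@H](O)[C@H]1O` is compound 2 with one change: 1-benzofuran-2-yl in place of thiophen-3-yl on an aromatic carbon. For the measured compounds named here, no measured pair isolates this swap, so its effect is not known directly. Going by the values given here, compound 1, which also carries 1-benzofuran-2-yl, gives 22400 nM, and this value is the only guide. A moderate move towards a lower number is therefore expected. The estimated change is a 2.8-fold lower number from compound 2 to compound 3 (0.44 log units; beyond the scatter). For compound 3 the expected value is 35000 nM, with an estimated range of 10000 nM to 90000 nM.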

Compound 3, half-maximal inhibitory concentration: 93900 nM
The estimate for compound 3 lay 2.7-fold (0.43 log units) below the measured number; the whole stated range lies below it.
By their numbers in this assay, from the lowest: compound 1; then compounds 3 and 2 (each within the scatter of the next).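

With methyl on the shared core, 1-benzofuran-2-yl in place of thiophen-3-yl on an aromatic carbon leaves the number in this assay unchanged (a 1.0-fold lower number from compound 2 to compound 3 (0.01 log units; within the scatter)), so the larger group gives no measurable gain in this setting. The lower number of compound 1 therefore does not carry over to every compound with 1-benzofuran-2-yl. With 1-benzofuran-2-yl held fixed, methyl in place of methoxy on an aromatic carbon gives a clear shift (a 4.2-fold higher number from compound 1 to compound 3 (0.62 log units; beyond the scatter)), although no measurement shown here explains that difference.

On these data alone, whether thiophen-3-yl and 1-benzofuran-2-yl would also match with methoxy on the core remains open. So does the effect of replacing methoxy with an amine or a longer chain such as ethoxy.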